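A few compounds are considered here, and "the series" means these few. Any claim that something is new, unique, unknown or untested is made for them only; others in the source may bear on it.

In a functional assay on CCRF-CEM cells (Homo sapiens) for antiproliferative activity, read by trypan blue exclusion, with a stated time of 72 h (on this read-out higher numbers stand for weaker inhibition and lower numbers for stronger inhibition), compound 1 `Cc1ccc(NC(=O)C(C)Br)cc1C(=O)NC(N)=O` gives only a limit of the assay, > 20000 nM. Compound 2 `CC(Br)C(=O)Nc1ccc(F)c(C(=O)NC(N)=O)c1` gives 520 nM in this assay. The change between them, (fluoro in place of methyl on an aromatic carbon), produced an at least 38-fold lower number from compound 1 to compound 2 (1.58 log units; beyond the scatter). Compound 3 `Cc1ccc(C(=O)NC(N)=O)cc1NC(=O)CCl` gives 3360 nM; how its core differs from that of compound 1 is not broken down here. Compound 4 `NC(=O)NC(=O)c1ccc(F)c(NC(=O)CCl)c1` is not yet measured; it differs from compound 3 by fluoro in place of methyl on an aromatic carbon, the same kind of change as from compound 1 to compound 2, though here the fluoro sits ortho to a ((chloromethyl)carbonyl)amino group and para to a carbamoylcarbamoyl group, rather than ortho to a carbamoylcarbamoyl group and para to a ((1-bromoethyl)carbonyl)amino group. Because compound 1 reached only the limit (the limit of > 20000 nM in this assay, at which 1 of the 3 values shown sits), the size of the earlier step is known only as a minimum. Compound 4 is expected, in this assay, to give 600 nM, which would mean a 5.6-fold lower number from compound 3 to compound 4 (0.75 log units; beyond the scatter), a clear improvement, estimated more cautiously since the surroundings of the change differ.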

Compound 4, half-maximal inhibitory concentration: > 20000 nM
Compound 4: only a limit was reported; the forecaster's own chance of this, stated with the estimate: 5%; at least 33-fold (1.52 log units) between middle value and limit.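

In this assay compound 4 gives > 20000 nM as its reading, which is a limit of the assay and not a number. Fluoro in place of methyl here brings an at least 5.9-fold higher number from compound 3 to compound 4 (0.77 log units; beyond the scatter), so the same swap moves the number in opposite directions on the two cores and cannot simply be carried from one to the other: the same change on two cores in this assay, an at least 38-fold lower number (1.58 log units; beyond the scatter) from compound 1 to compound 2 and an at least 5.9-fold higher number (0.77 log units; beyond the scatter) from compound 3 to compound 4, at least 220-fold (2.35 log units) apart, beyond the scatter of two such steps. Both steps are known only as minimum sizes, and nothing here shows why the two cores part ways, as each step rests on a limit: the limit of > 20000 nM in this assay, at which 2 of the 4 values shown sit. Left open is how a methoxy group or a nitrile would fare at that aromatic carbon on either core. Equally open, going by these compounds, is how a longer chain in place of the chloromethyl group would read.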